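One aryl group for another at the weak end

The source may hold more compounds than are shown below. What is called first, only, known or untested is meant among the compounds shown, and "the series" means these compounds.

In a functional assay on Z-138 cells (Homo sapiens) for antiproliferative activity, with a stated time of 72 h (a higher number here means a weaker inhibitor, a lower number a stronger inhibitor), compound 1 `Nc1ncnn2c([C@@H]3O[C@H](CO)[C@@H](O)[C@H]3O)cc(C#CC3CC3)c12` gives 20 nM as its value, compound 2 `Nc1ncnn2c([C@@H]3O[C@H](CO)[C@@H](O)[C@H]3O)cc(C#Cc3ccc(F)cc3)c12` gives 89000 nM as its value and compound 3 `Nc1ncnn2c([C@@H]3O[C@H](CO)[C@@H](O)[C@H]3O)cc(-c3ccc(F)cc3F)c12` gives 59100 nM as its value. Compound 3 thus stands with compound 2 at the weak end of the three, the pair lying within the scatter of each other and far from compound 1. The next structure is compound 4 `COc1ccc(-c2cc([C@@H]3O[C@H](CO)[C@@H](O)[C@H]3O)n3ncnc(N)c23)cc1` with 4-methoxyphenyl in place of 2,4-difluorophenyl on an aromatic carbon. Its difference is 4-methoxyphenyl in place of 2,4-difluorophenyl on an aromatic carbon at a five-membered aromatic ring with 1 nitrogen. Two measured steps were large, with a 4500-fold higher number from compound 1 to compound 2 (3.65 log units; beyond the scatter) and a 3000-fold higher number from compound 1 to compound 3 (3.47 log units; beyond the scatter) on record, and both start from the 2-cyclopropylethynyl group of compound 1. Compound 4 keeps no such group. For the measured compounds named here, the closer guide is a 1.5-fold lower number from compound 2 to compound 3 (0.18 log units; within the scatter) as a step that stayed within the scatter, although no measured step exchanges one substituted phenyl directly for another. In this assay the expected step is a 1.2-fold lower number from compound 3 to compound 4 (0.07 log units; within the scatter) and no change beyond the scatter is expected. For compound 4 the estimated value is 50000 nM with an expected range from 15000 nM to 100000 nM in this read-out.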

Compound 4, half-maximal inhibitory concentration: 62600 nM
Estimate against measurement, compound 4: 1.3-fold (0.10 log units) below, within the range that was stated.
By their numbers in this assay, from the lowest: compound 1; then compounds 3, 4 and 2 (each within the scatter of the next).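

In this assay, exchanging one directly attached substituted phenyl for another at this aromatic carbon of the five-membered ring gave a 1.1-fold higher number from compound 3 to compound 4 (0.02 log units; within the scatter), even though 4-methoxyphenyl counts a hydrogen-bond acceptor and 2,4-difluorophenyl counts none. For the compounds shown here, this is the first direct comparison of two such phenyl groups at the position, and in this pair neither the two fluorines nor the methoxy group separates the compounds. The result also gives a 1.4-fold lower number from compound 2 to compound 4 (0.15 log units; within the scatter) against the ethynyl-linked 2-(4-fluorophenyl)ethynyl group, while a 3100-fold higher number from compound 1 to compound 4 (3.50 log units; beyond the scatter) places a third phenyl-bearing compound far from the cyclopropylethynyl compound, so all of compounds 2, 3 and 4 lie well apart from compound 1.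

The data at hand offer no measurement that accounts for this grouping or for the gap to compound 1. From the compounds shown here alone, it remains open whether the strong value of compound 1 depends on the cyclopropyl group, the triple bond or both, and whether a directly attached cyclopropyl, a short alkyl chain on the triple bond, or an amine or carboxylic acid on the phenyl ring would move the value away from the weak end.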